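The source may hold more compounds than are shown below. What is called first, only, known or untested is meant among the compounds shown, and "the series" means these compounds.

In a functional assay on PC-3 cells (Homo sapiens) for cytotoxicity (a higher number here means that more compound is needed for the effect, a lower number that less compound is needed), compound 1 `COC1=C(C)C(=O)/C(=C(O)/C=C/c2ccc(O)cc2)C(=O)C1(C)C` reads > 20 ug/mL, which is a limit and not a number. Among the measured compounds shown here, compound 2 `C=Cc1ccccc1/C=C/C(O)=C1/C(=O)C(C)=C(OC)C(C)(C)C1=O` gives 4.6 ug/mL, the only actual number so far in this assay. For the measured compounds named here, only one measured step bears on what follows, and it changes the same place: 2-vinylphenyl in place of 4-hydroxyphenyl gave an at least 4.3-fold lower number from compound 1 to compound 2 (0.63 log units; beyond the scatter). Compound 3 `COC1=C(C)C(=O)/C(=C(O)/C=C/c2cccs2)C(=O)C1(C)C` carries thiophen-2-yl in place of 2-vinylphenyl on a double-bonded chain carbon bound to a double-bonded chain carbon. Compound 3 gives up the 2-vinylphenyl group that came with an at least 4.3-fold lower number from compound 1 to compound 2 (0.63 log units; beyond the scatter), so part of that drop may be undone and a modest rise in the number is expected. The expected change is a 2.4-fold higher number from compound 2 to compound 3 (0.38 log units; beyond the scatter). For compound 3 the estimate is 11 ug/mL, with an expected range from 4 ug/mL to 30 ug/mL.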

Compound 3, concentration for half-maximal effect: 18.2 ug/mL
The estimate for compound 3 lay 1.7-fold (0.22 log units) below the measured number, within the range that was stated.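

Among the compounds shown here, replacing 2-vinylphenyl with thiophen-2-yl gave a 4.0-fold higher number from compound 2 to compound 3 (0.60 log units; beyond the scatter), the first step at this place in this assay with a real number at both ends. All three compounds carry an aromatic ring here, yet compound 2 has the lowest number, with steps to both others beyond the scatter, so an aromatic ring alone does not bring the low number of compound 2. Thiophen-2-yl in place of 4-hydroxyphenyl gave an at least 1.0-fold lower number from compound 1 to compound 3 (0.04 log units; that floor lies within the scatter), and this floor cannot rank the two groups because compound 1 is known only through a limit: the limit of > 20 ug/mL in this assay, at which 1 of the 3 values shown sits.

On these data alone, it remains open whether the low number of compound 2 depends on the vinyl group or on the benzene ring that carries it. A plain phenyl or a 2-ethylphenyl group at this place would help separate the two, and a 2-aminophenyl group would show whether an amine is tolerated there.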